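A few compounds are considered here, and "the series" means these few. Any claim that something is new, unique, unknown or untested is made for them only; others in the source may bear on it.

Two macrocyclic compounds have been measured in an ADME assay on cells (Homo sapiens) for activation; a higher number here means that more compound is tolerated, a lower number that less compound is tolerated. Compound 1 `CCCn1cc(-c2cc(OCC[C@@H]3NC(=O)N(C)CCCC/C=C\[C@@H]4C[C@@]4(C(=O)NS(=O)(=O)C4(C)CC4)NC3=O)c3ccc(OC)c(C)c3n2)cn1` gives 62300 nM in this assay. Compound 2 `COc1ccc2c(OCC[C@@H]3NC(=O)N(C)CCCC/C=C\[C@@H]4C[C@@]4(C(=O)NS(=O)(=O)C4(C)CC4)NC3=O)cc(-n3ccc(C(C)C)n3)nc2c1Cl`, which carries a different substituted pyrazole and a differently decorated core, gives 31000 nM in this assay. These two numbers lie within the usual scatter of each other, so neither compound can be said to be tolerated better than the other. Compound 3 `CCn1cc(-c2cc(OCC[C@@H]3NC(=O)N(C)CCCC/C=C\[C@@H]4C[C@@]4(C(=O)NS(=O)(=O)C4(C)CC4)NC3=O)c3ccc(OC)c(C)c3n2)cn1` has not yet been measured. It differs from compound 1 in one place only: hydrogen in place of methyl on a saturated chain carbon, two bonds along the chain from an aromatic nitrogen. For the measured compounds named here, a methyl lost from a short chain on the pyrazole is a modest change, and no measured pair here shows how such a change moves this assay. The expectation is therefore a step of a 1.1-fold lower number from compound 1 to compound 3 (0.05 log units; within the scatter) that stays within the scatter, in no particular direction. Compound 3 is expected to give about 55000 nM in this assay, with a likely range from 25000 nM to 120000 nM.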

Compound 3, half-maximal cytotoxic concentration: 36700 nM
For compound 3 the middle estimate is 1.5-fold (0.18 log units) above the measured one, within the range that was stated.
By their numbers in this assay, from the lowest: compounds 2, 3 and 1 (each within the scatter of the next).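

For the compounds shown here, replacing 1-propyl-1H-pyrazol-4-yl with 1-ethyl-1H-pyrazol-4-yl on an otherwise identical structure gives the first step that can be read for a single change in this assay: a 1.7-fold lower number from compound 1 to compound 3 (0.23 log units; within the scatter). At this position, then, the loss of one carbon from the chain gives a step that cannot be told apart from the differences seen between repeated measurements. Nothing available explains the size of this step.

The compounds shown leave open whether a longer chain such as butyl, or a chain ending in an amine or a carboxylic acid, would give a step beyond the scatter at this position. They also leave open whether propyl and ethyl would compare in the same way on a different core.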